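The source may hold more compounds than are shown below. What is called first, only, known or untested is meant among the compounds shown, and "the series" means these compounds.

Measured compounds:
- Compound 3 `COc1ccc(-c2cc(NC(=O)COCC(=O)NCC(=O)NC3CCCCC3)nc(-c3ccc(OC)cc3)n2)cc1`: 14000 nM
- Compound 1 `COc1ccc(-c2cc(NC(=O)CCC(=O)NCC(=O)NC(C)(C)C)nc(-c3ccc(OC)cc3)n2)cc1`: 15000 nM
- Compound 2 `COc1ccc(-c2cc(NC(=O)CCC(=O)NCC(=O)NCc3ccccc3)nc(-c3ccc(OC)cc3)n2)cc1`: 26900 nM

All three share one core and differ only in the chain that hangs from the amide nitrogen. In an assay on HeLa cells for displacement of a labelled ligand from adenosine receptor A3 (Homo sapiens), read by fluorescence polarization, with a stated time of 30 min (on this read-out lower numbers stand for stronger inhibition and higher numbers for weaker inhibition), compound 3 gives 14000 nM, compound 1 gives 15000 nM and compound 2 gives 26900 nM. Compound 3 has the lowest of the three numbers, but its gaps to compound 1 and to compound 2 both lie within the scatter, so no order among them can be read.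

Compound 4 `COc1ccc(-c2cc(NC(=O)COCC(=O)N(C)CC(=O)NC(C)(C)C)nc(-c3ccc(OC)cc3)n2)cc1` has not been measured. It differs from compound 3 by methyl(((tert-butyl)carbamoyl)methyl)amino in place of ((cyclohexylcarbamoyl)methyl)amino on a carbonyl carbon. For the measured compounds named here, only one measured step touches the same region: a 1.8-fold higher number from compound 1 to compound 2 (0.25 log units; within the scatter), where the group on the terminal amide nitrogen was exchanged without a shift beyond the scatter. Going by the values given here, compounds 1 and 3 differ in two places, so their near-identical numbers show only that those two changes together left the read-out where it was. Among the compounds with values here, the methyl now placed on the middle nitrogen has no counterpart among the measured compounds. Taken together, the expected step is a 1.1-fold higher number from compound 3 to compound 4 (0.03 log units; within the scatter), essentially none beyond the scatter. Compound 4 is therefore expected to give about 15000 nM in this assay, with a range from 6000 nM to 40000 nM.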

Compound 4, inhibition constant: 7200 nM
The estimate for compound 4 lay 2.1-fold (0.32 log units) above the measured number; the measured number falls inside the stated range.
By their numbers in this assay, from the lowest: compounds 4, 3, 1 and 2 (each within the scatter of the next, the first and the last beyond it).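

In this assay, replacing ((cyclohexylcarbamoyl)methyl)amino with methyl(((tert-butyl)carbamoyl)methyl)amino on a carbonyl carbon gives a 1.9-fold lower number from compound 3 to compound 4 (0.29 log units; within the scatter). This swap removes the six-membered ring and leaves one hydrogen-bond donor fewer, yet the number does not move beyond the scatter, so neither the ring nor that donor is shown to be needed for this read-out. No measurement shown here offers an explanation for this small step.

As far as these compounds go, the swap adds the methyl and exchanges cyclohexyl for tert-butyl together, so the part played by each stays open, and a compound with the methyl and cyclohexyl together would separate them. Also open, from the compounds shown here alone, is how this read-out would respond to an amine, a carboxylic acid or a longer chain in this place.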